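The source may hold more compounds than are shown below. What is called first, only, known or untested is meant among the compounds shown, and "the series" means these compounds.

Measured compounds in a functional assay on MCF7 cells (Homo sapiens) for cytotoxicity, read by MTT assay, with a stated time of 24 h; on this read-out higher numbers stand for weaker inhibition and lower numbers for stronger inhibition:
compound 1 `FC(F)(F)C(F)(F)C(F)(F)C(F)(F)C(F)(F)C(F)(F)CCn1cc(COc2ccccc2-c2nc3ccccc3s2)nn1`: 19800 nM
compound 2 `Fc1ccc(-n2cc(COc3ccccc3-c3nc4ccccc4s3)nn2)cc1`: 26200 nM
compound 3 `Brc1ccc(-c2cc(COc3ccccc3-c3nc4ccccc4s3)on2)cc1`: 20000 nM

Compound 1 carries the lowest number of the three in this assay, but its nearest neighbour, compound 3, and its furthest, compound 2, both sit within the usual scatter of it, so no ranking among the three is supported. Compound 4 `FC(F)(F)C(F)(F)C(F)(F)C(F)(F)C(F)(F)C(F)(F)C(F)(F)C(F)(F)CCn1cc(COc2ccccc2-c2nc3ccccc3s2)nn1` differs from compound 1 in one place: 1,1,2,2,2-pentafluoroethyl in place of fluoro on a saturated chain carbon bound to two fluorine atoms and a saturated chain carbon. Going by the values given here, no measured pair differs in a single place, so no step size is on record for comparison. Given that the three measured values cluster so closely, the expected step in this assay is none beyond the scatter, as a 1.0-fold higher number from compound 1 to compound 4 (0.00 log units; within the scatter). Compound 4 is estimated at 20000 nM, with a range from 9000 nM to 45000 nM.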

Compound 4, half-maximal inhibitory concentration: 19200 nM
Compound 4: middle estimate off by 1.0-fold (0.02 log units), on the high side; low and high end bracket the measured number.
By their numbers in this assay, from the lowest: compounds 4, 1, 3 and 2 (each within the scatter of the next).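

In this assay, the first pair differing in one place gives a 1.0-fold lower number from compound 1 to compound 4 (0.01 log units; within the scatter), with 1,1,2,2,2-pentafluoroethyl in place of fluoro on a saturated chain carbon bound to two fluorine atoms and a saturated chain carbon. At this position, the larger fluorinated end does not separate the two compounds on this read-out. Nothing on record offers an explanation for this flat result.

As far as these compounds go, whether a non-fluorinated alkyl chain, or an amine or carboxylic acid at the chain end, would depart from this level remains open. Also open, from the compounds shown here alone, is whether any change to the shared core gives a step beyond the scatter.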